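Amide cap variation on the pyrrolidine acyl group

The source may report more compounds than this note shows. Statements on the series, on what has been measured and on what is new or still open speak of the compounds shown alone.

Three compounds share a core and differ only in the acyl cap. In an assay on isolated protein for binding affinity to secreted frizzled-related protein 1 (Homo sapiens), read by fluorescence (a lower number here means a stronger inhibitor, a higher number a weaker inhibitor), compound 1 `CN(C)CC(=O)N1CCC(NS(=O)(=O)c2cc(S(=O)(=O)c3ccccc3)ccc2C(F)(F)F)CC1` gives 300 nM, compound 2 `CC(C)(C)CC(=O)N1CCC[C@H]1C(=O)N1CCC(NS(=O)(=O)c2cc(S(=O)(=O)c3ccccc3)ccc2C(F)(F)F)CC1` gives 20 nM and compound 3 `CN(C)c1ccc(C(=O)N2CCC[C@H]2C(=O)N2CCC(NS(=O)(=O)c3cc(S(=O)(=O)c4ccccc4)ccc3C(F)(F)F)CC2)cc1` gives 110 nM. Compound 3 thus sits second highest of the three, between compound 1 and compound 2. The step of a 15-fold lower number from compound 1 to compound 2 (1.18 log units; beyond the scatter) was large; the step of a 5.5-fold higher number from compound 2 to compound 3 (0.74 log units; beyond the scatter) was modest.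

Compound 4 `CN(C)C(=O)N1CCC[C@H]1C(=O)N1CCC(NS(=O)(=O)c2cc(S(=O)(=O)c3ccccc3)ccc2C(F)(F)F)CC1` carries dimethylamino in place of 4-(dimethylamino)phenyl on a carbonyl carbon. Among the measured compounds shown here, no measured step replaces an aryl cap by a dimethylamino cap, so the two steps bear on it only loosely: the step from compound 2 to compound 3 shows that the cap on this carbonyl carbon can move this assay by a modest margin, and compound 1, with the smallest cap, sits highest. A smaller cap than in compound 3 is therefore expected to give at most a modest change, with direction uncertain, so compound 4 is estimated at 120 nM in this assay, range 35 nM to 400 nM, a step of a 1.1-fold higher number from compound 3 to compound 4 (0.04 log units; within the scatter) expected.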

Compound 4, half-maximal inhibitory concentration: 30 nM
Compound 4: the middle estimate sits 4.0-fold (0.60 log units) above what was measured, and the stated range ends above it.
By their numbers in this assay, from the lowest: compounds 2 and 4 (each within the scatter of the next); then compound 3; then compound 1.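

Replacing 4-(dimethylamino)phenyl with dimethylamino on this carbonyl carbon gives a 3.7-fold lower number from compound 3 to compound 4 (0.56 log units; beyond the scatter) in this assay, so the aromatic ring of the cap is not required at this position. The dimethylamino and neopentyl caps are not separated, with a 1.5-fold higher number from compound 2 to compound 4 (0.18 log units; within the scatter) in this assay, and of the caps on the acylated pyrrolidine only 4-(dimethylamino)phenyl reads differently, on the weaker side. The change to 1-(dimethylcarbamoyl)pyrrolidin-2-yl from (dimethylamino)methyl gives a 10-fold lower number from compound 1 to compound 4 (1.00 log units; beyond the scatter) in this assay, so a cap as small as dimethylamino is compatible with a low number once the pyrrolidine unit is present.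

No measurement shown bears on the reason for these differences. Open, as far as these compounds go, is how a morpholine or methoxy cap, or a carboxylic acid on the cap, would read in this assay at this carbonyl carbon.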